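Aryl swap from compound 2 to compound 3

The source may hold more compounds than are shown below. What is called first, only, known or untested is meant among the compounds shown, and "the series" means these compounds.

Of the compounds shown here, two have numbers so far. In an ADME assay on HEK293 cells (Homo sapiens) for cytotoxicity, read by MTT assay, with a stated time of 24 h (a lower number here means a stronger inhibitor, a higher number a weaker inhibitor), compound 1 (`O=[N+]([O-])c1ccc2nc(NCc3ccc(C(F)(F)F)cc3)c(N3CCNCC3)nc2c1`) gives 9.61 ug/mL and compound 2 (`Cc1ccc(CNc2nc3ccc([N+](=O)[O-])cc3nc2NCCCN(C)C)cc1`) gives 15.8 ug/mL so compound 2 stands within the scatter of compound 1 and the pair cannot be separated on these numbers.

Compound 3 (`CN(C)CCCNc1nc2cc([N+](=O)[O-])ccc2nc1NCc1cccc(C(F)(F)F)c1`) has not yet been measured. It differs from compound 2 in one place: 3-(trifluoromethyl)phenyl in place of 4-methylphenyl on a saturated chain carbon bound to a nitrogen on an aromatic ring.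

Going by the values given here, no measured pair isolates this swap, so the expectation rests on very little. Compound 1 also carries a trifluoromethyl group and gives 9.61 ug/mL in this assay so no step beyond the scatter is expected, with at most a slight lean toward a lower number. The estimated change is a 1.3-fold lower number from compound 2 to compound 3 (0.12 log units; within the scatter) and would stay within the scatter. Compound 3 is expected at 12 ug/mL with an estimated range from 5 ug/mL to 28 ug/mL in the same read-out.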

Compound 3, half-maximal inhibitory concentration: 7.99 ug/mL
Beside the measured number, compound 3's estimate is 1.5-fold (0.18 log units) above it, within the range that was stated.
By their numbers in this assay, from the lowest: compounds 3, 1 and 2 (each within the scatter of the next).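

In this assay, going by these compounds alone, 3-(trifluoromethyl)phenyl in place of 4-methylphenyl on a saturated chain carbon bound to a nitrogen on an aromatic ring gives a 2.0-fold lower number from compound 2 to compound 3 (0.30 log units; within the scatter), and this is the first pair that differs in one place only. The aryl group at this position can therefore go from 7 to 10 heavy atoms, and take on 3 fluorine atoms, with no step beyond the scatter, so compound 2 and compound 3 cannot be told apart on these numbers. Nothing at hand accounts for the size of this step, and one pair sets no trend for the position.

The swap alters both the substituent and its place on the phenyl ring, so this pair cannot separate the two changes; 3-methylphenyl or 4-(trifluoromethyl)phenyl on the same dimethylaminopropyl-bearing core would divide them. Also open, on these data alone, is whether any group at this position moves the number beyond the scatter, for example unsubstituted phenyl, a methoxyphenyl or a pyridyl ring, and whether the same holds with a longer amine chain in the other place.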